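A few compounds are considered here, and "the series" means these few. Any claim that something is new, unique, unknown or untested is made for them only; others in the source may bear on it.

Three compounds share one core and differ only in the group sitting on a saturated chain carbon bound to an amine nitrogen. Compound 1 `CN(Cc1ccsc1)C1CCN(CCCc2c[nH]c3ccc(-n4cnnc4)cc23)CC1` carries thiophen-3-yl there, and in an assay on CHO cells for displacement of a labelled ligand from 5-hydroxytryptamine receptor 1D (Homo sapiens) (a higher number here means a weaker inhibitor, a lower number a stronger inhibitor), compound 1 gives 1.5 nM. Compound 2 `CN(Cc1ccc(S(C)(=O)=O)cc1)C1CCN(CCCc2c[nH]c3ccc(-n4cnnc4)cc23)CC1` carries 4-(methylsulfonyl)phenyl, and compound 2 gives 18 nM. Compound 3 `CC(C)=CCN(C)C1CCN(CCCc2c[nH]c3ccc(-n4cnnc4)cc23)CC1` carries 2-methylprop-1-en-1-yl, and compound 3 gives 0.5 nM, the lowest number of the three, since the step of a 3.0-fold lower number from compound 1 to compound 3 (0.48 log units; beyond the scatter) and the step of a 36-fold lower number from compound 2 to compound 3 (1.56 log units; beyond the scatter) both lie beyond the scatter.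

Compound 4 `CC(=O)Nc1ccc(CN(C)C2CCN(CCCc3c[nH]c4ccc(-n5cnnc5)cc34)CC2)cc1` has not yet been measured. It differs from compound 3 by 4-acetamidophenyl in place of 2-methylprop-1-en-1-yl on a saturated chain carbon bound to an amine nitrogen. The step of a 36-fold lower number from compound 2 to compound 3 (1.56 log units; beyond the scatter) bears most directly on this change. There a six-membered aromatic ring carrying a hydrogen-bond acceptor gave way to the same alkenyl group; the step of a 3.0-fold lower number from compound 1 to compound 3 (0.48 log units; beyond the scatter) points the same way but is smaller. Compound 4 reverses that direction, bringing back an aromatic ring that carries a hydrogen-bond donor and acceptor, so a clearly higher number is expected. Compound 4 is therefore estimated at 10 nM, between 3 nM and 40 nM. For compound 4 the expected step is a 20-fold higher number from compound 3 to compound 4 (1.30 log units; beyond the scatter).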

Compound 4, half-maximal inhibitory concentration: 19 nM
The estimate for compound 4 lay 1.9-fold (0.28 log units) below the measured number; the measured number falls inside the stated range.
By their numbers in this assay, from the lowest: compound 3; then compound 1; then compounds 2 and 4 (each within the scatter of the next).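

Replacing methylsulfonyl with acetamido on an aromatic carbon leaves the number in this assay essentially unchanged, with a 1.1-fold higher number from compound 2 to compound 4 (0.02 log units; within the scatter), so the high number of compound 2 is not peculiar to its methylsulfonyl group. The steps of a 38-fold higher number from compound 3 to compound 4 (1.58 log units; beyond the scatter) and a 13-fold higher number from compound 1 to compound 4 (1.10 log units; beyond the scatter) show the same high level with a second substituted phenyl ring on a saturated chain carbon bound to an amine nitrogen, and in these four compounds both such rings sit well above the thiophen-3-yl and 2-methylprop-1-en-1-yl groups. No measurement is available here to explain why these numbers differ.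

Still open, as far as these compounds go, is whether the phenyl ring itself or the presence of a substituent on it accounts for the rise, which unsubstituted phenyl could separate. From the compounds shown here alone, whether a carboxylic acid or an aminomethyl group on that ring would also give the same level remains unknown too.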